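The compounds below may be only part of what the source reports. "The series", "measured", "known", "first", "only" and "open" are said of these compounds alone.

Working notes on the series. Compound 1 `COC1Cc2c(cnn2-c2ccccc2)C2(CCNCC2)O1` carries an unsubstituted ring amine, and in an assay for displacement of a labelled ligand from Sigma non-opioid intracellular receptor 1 (Cavia porcellus), read by scintillation counting, with a stated time of 180 min (on this read-out lower numbers stand for stronger inhibition and higher numbers for weaker inhibition), compound 1 gives only a limit, > 1000 nM. Compound 2 `COC1Cc2c(cnn2-c2ccccc2)C2(CCN(Cc3ccco3)CC2)O1` adds a (furan-2-yl)methyl group on that nitrogen; in this assay compound 2 gives 2.2 nM. The step of an at least 450-fold lower number from compound 1 to compound 2 (2.65 log units; beyond the scatter) shows how much the substituent on the ring amine carries, starting from the limit of > 1000 nM in this assay, at which 1 of the 3 values shown sits. Among the compounds with values here, compound 3 `COC1Cc2c(cnn2C)C2(CCN(Cc3ccc(F)cc3)CC2)O1` differs from compound 2 in two places, so no single step links them; in this assay compound 3 gives 21 nM, the higher of the two numbers on record, and its gap to compound 2 is beyond the scatter.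

Compound 4 `COC1Cc2c(cnn2C)C2(CCN(CCC(C)C)CC2)O1` is compound 3 with isobutyl in place of 4-fluorophenyl on a saturated chain carbon bound to an amine nitrogen in a ring. Within the data shown here, no measured step covers exchanging an aromatic ring for a branched chain here; the step from compound 1 to compound 2 bears on it only by showing that a substituent on the ring amine is needed, and isopentyl keeps one in place. A moderate weakening is expected, a 2.9-fold higher number from compound 3 to compound 4 (0.46 log units; beyond the scatter). Compound 4 is therefore expected to give 60 nM in this assay, between 15 nM and 250 nM.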

Compound 4, inhibition constant: 18 nM
Estimate against measurement, compound 4: 3.3-fold (0.52 log units) above; the range from low to high includes it.
By their numbers in this assay, from the lowest: compound 2; then compounds 4 and 3 (each within the scatter of the next). At a limit, above all of these: compound 1.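

In this assay, the exchange gives a 1.2-fold lower number from compound 3 to compound 4 (0.07 log units; within the scatter), so on the core of compound 3 an aromatic ring on this saturated chain carbon bound to an amine nitrogen in a ring is not required: isobutyl, which has no ring, and 4-fluorophenyl cannot be told apart here. The earlier step showed only that a substituent on the ring amine matters, with a ring-bearing group as the example; this one shows that a purely open-chain substituent can also serve on this core. No measured property on hand accounts for this result.

On these data alone, whether isobutyl and 4-fluorophenyl would also match on the core of compound 2 remains open. Also open, as far as these compounds go, is how a longer chain, or a chain ending in a hydroxyl group or a carboxylic acid, would read at this place.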